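A few compounds are considered here, and "the series" means these few. Any claim that something is new, unique, unknown or untested is made for them only; others in the source may bear on it.

Measured compounds:
compound 1 `CC1CCCN1C1CCN(c2ccc(NC(=O)Nc3cc(Cl)cc(Cl)c3)cc2)C1`, 19.1 nM
compound 2 `CC(=O)N1CCN(C(=O)Nc2ccc(N3CCC(N4CCCC4C)C3)cc2)CC1`, 34.1 nM
compound 3 `CC1CCCN1C1CCN(c2ccc(NC(=O)N3CCCCC3)cc2)C1`, 6 nM

In an assay on CHO cells for displacement of a labelled ligand from histamine receptor H3 (Macaca mulatta), read by scintillation counting, with a stated time of 1 h (a lower number here means a stronger inhibitor, a higher number a weaker inhibitor), compound 3 gives the lowest number of the three. Compound 1 sits a 3.2-fold lower number from compound 1 to compound 3 (0.50 log units; beyond the scatter) away from it and compound 2 sits a 5.7-fold lower number from compound 2 to compound 3 (0.75 log units; beyond the scatter) away, so compound 3 stands alone at the strong end of this small set, both gaps being beyond the scatter.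

Compound 4 `CC1CCCN1C1CCN(c2ccc(NC(=O)NCc3cccs3)cc2)C1` has not yet been measured. It differs from compound 3 in one place: ((thiophen-2-yl)methyl)amino in place of piperidin-1-yl on a carbonyl carbon. For the measured compounds named here, two measured steps bear on exchanges at this carbonyl carbon. Going from the piperidin-1-yl of compound 3 to the (3,5-dichlorophenyl)amino of compound 1 raised the number by the amount of a 3.2-fold lower number from compound 1 to compound 3 (0.50 log units; beyond the scatter) read in reverse, and going to the 4-acetylpiperazin-1-yl of compound 2 raised it by a 5.7-fold lower number from compound 2 to compound 3 (0.75 log units; beyond the scatter) read in reverse. Both replacements of the piperidin-1-yl cost potency, and the ((thiophen-2-yl)methyl)amino of compound 4, like the group in compound 1, brings an amino hydrogen-bond donor in place of the ring nitrogen. Compound 4 is therefore expected to show a modest weakening, a 2.5-fold higher number from compound 3 to compound 4 (0.40 log units; beyond the scatter), beyond the scatter but less than the fall seen for compound 2. Compound 4 is estimated at 15 nM, with a range from 5 nM to 45 nM.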

Compound 4, inhibition constant: 1.9 nM
For compound 4 the middle estimate is 7.9-fold (0.90 log units) above the measured one, outside the stated range (below it).
By their numbers in this assay, from the lowest: compound 4; then compound 3; then compounds 1 and 2 (each within the scatter of the next).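

In this assay, ((thiophen-2-yl)methyl)amino is the only exchange shown at this carbonyl carbon that lowers the number, with a 3.2-fold lower number from compound 3 to compound 4 (0.50 log units; beyond the scatter) standing beyond the scatter, so piperidin-1-yl is not the best group seen here. The amino group alone does not set the number: compounds 1 and 4 both carry it, yet a 10-fold lower number from compound 1 to compound 4 (1.00 log units; beyond the scatter) follows from (thiophen-2-yl)methyl in place of 3,5-dichlorophenyl on the amide-type nitrogen. The span at this position also widens, with an 18-fold lower number from compound 2 to compound 4 (1.25 log units; beyond the scatter) as the largest step in the set.

The compounds shown leave open whether a benzylamino or a ((furan-2-yl)methyl)amino group would give a number like that of compound 4, and so whether the thiophene ring itself matters. No evidence is available to explain the gain seen with compound 4.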